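Aryl versus phenethyl at the core of compound 1

This account rests on a few compounds, and the source may have more. Where it says the series, first, only, none or still open, it means among the compounds named here.

Measured so far:
compound 1 `CC(C(=O)NCc1ccc(C(F)(F)F)nc1-c1ccc(Cl)c(Cl)c1)c1ccc(NS(C)(=O)=O)c(F)c1` — 0.9 nM in an assay on CHO cells for antagonist activity at transient receptor potential cation channel subfamily V member 1 (Homo sapiens), read by FLIPR; on this read-out lower numbers stand for stronger inhibition and higher numbers for weaker inhibition
compound 2 `COc1ccc(-c2nc(C(F)(F)F)ccc2CNC(=O)C(C)c2ccc(NS(C)(=O)=O)c(F)c2)cc1F` — 4.2 nM in this assay

Within the data shown here, compound 1 stands at the lowest of the two numbers in this assay; its only neighbour is compound 2, and the step of a 4.7-fold higher number from compound 1 to compound 2 (0.67 log units; beyond the scatter) is a modest loss that lies beyond the scatter. In that step one aromatic ring is exchanged for another at the same aromatic carbon of the core.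

Compound 3 `CC(C(=O)NCc1ccc(C(F)(F)F)nc1CCc1ccccc1)c1ccc(NS(C)(=O)=O)c(F)c1` is the next case. The change is phenethyl in place of 3,4-dichlorophenyl on an aromatic carbon. Among the measured compounds shown here, the one measured step that bears on it is a 4.7-fold higher number from compound 1 to compound 2 (0.67 log units; beyond the scatter), where the aromatic ring stayed directly on the core and only its substituents changed. In compound 3 the aromatic ring is no longer attached directly but through the phenethyl group, a larger departure from compound 1 than the one already measured. A step toward weaker inhibition in this assay, larger than the measured one, is therefore expected.

For compound 3 the expected value in this assay is 15 nM, with a range of 3 nM to 80 nM. This estimate means a 17-fold higher number from compound 1 to compound 3 (1.22 log units; beyond the scatter) as an expected step.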

Compound 3, inhibition constant: 1.4 nM
Beside the measured number, compound 3's estimate is 11-fold (1.03 log units) above it; the measured number lies below the stated range.
By their numbers in this assay, from the lowest: compounds 1 and 3 (each within the scatter of the next); then compound 2.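

Working from this assay, the phenethyl group of compound 3 and the 3,4-dichlorophenyl group of compound 1 cannot be told apart at this aromatic carbon next to the ring nitrogen, with a 1.6-fold higher number from compound 1 to compound 3 (0.19 log units; within the scatter) as the printed step. Within these three compounds, then, neither direct attachment of the aromatic ring to the core nor the two chlorine atoms are needed to reach the low end of the range seen so far. Compound 2 goes against reading direct attachment as an advantage in itself, since it retains a directly attached aromatic ring and yet a 3.0-fold lower number from compound 2 to compound 3 (0.48 log units; beyond the scatter) runs in favour of the phenethyl group, a modest step beyond the scatter. Nothing on hand accounts for why the phenethyl group is tolerated here.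

Going by these compounds, it remains open how far the link can vary at this carbon, for instance with a benzyl group or a longer chain such as 3-phenylpropyl, and whether the aromatic ring is needed at all, as a butyl chain or an amine such as piperidine would show. Also open, on these data alone, is whether chlorine atoms on the ring of the phenethyl group would change the number.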